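The compounds below may be only part of what the source reports. "The series", "measured", "known", "first", "only" and "open" are said of these compounds alone.

Compound 1 `CCC(CC)c1ccc2c(NCCCNCc3cccc(OC)c3O)ccnc2c1` is measured in an ADME assay for permeability, using PAMPA, with a stated time of 30 min, at pH 7.4 (a higher number here means that the compound crosses the layer faster, a lower number that the compound crosses the layer more slowly), where compound 1 gives 23 10^-6 cm/s. Two companions share its core. Compound 2 `c1ccc(CCc2ccc3c(NCCCNCc4ccco4)ccnc3c2)cc1` gives 23 10^-6 cm/s, and compound 3 `CCC(CC)c1ccc2c(NCCCNCc3cc(F)ccc3OC)ccnc2c1` gives 23 10^-6 cm/s, so compound 1 stands level with both at the digits shown. For the measured compounds named here, the only direct comparison among them, no change at the digits printed from compound 1 to compound 3 (within the scatter), swaps the group on the chain carbon bound to the amine nitrogen and leaves the read-out where it was.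

Compound 4 `COc1cccc(CNCCCNc2ccnc3cc(CC(C)C)ccc23)c1O` is not yet measured. It differs from compound 1 in one place: isobutyl in place of pentan-3-yl on an aromatic carbon. Going by the values given here, no measured step touches this position; the one known step, no change at the digits printed from compound 1 to compound 3 (within the scatter), concerns a different part of the molecule and was flat, and all three measured compounds sit together despite their varied side groups. With nothing pointing either way, the expected step is no change at the digits printed from compound 1 to compound 4 (within the scatter), that is, none beyond the scatter. Compound 4 is therefore expected to give about 23 10^-6 cm/s, within a range of 12 10^-6 cm/s to 40 10^-6 cm/s.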

Compound 4, apparent permeability: 23 10^-6 cm/s
Compound 4: the middle estimate sits on the measured number at the digits printed, and the stated range covers the measured number.
By their numbers in this assay, from the lowest: compounds 1, 2, 3 and 4 (each within the scatter of the next).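

For the compounds shown here, this is the first measured step at this aromatic carbon: in this assay, isobutyl in place of pentan-3-yl gives no change at the digits printed from compound 1 to compound 4 (within the scatter). Going by these compounds alone, the one earlier step concerned a different part of the molecule, so the read-out is now seen to hold through a change here as well, from a group of 5 heavy atoms to one of 4. Both groups are open carbon chains with no ring, no hydrogen-bond donors or acceptors and no net charge, and no measured evidence explains the flat result.

On these data alone, whether the read-out would hold with a different kind of group on this carbon, such as a carboxylic acid or a morpholine ring, remains open. Also open, as far as these compounds go, is whether isobutyl would give the same read-out alongside the 5-fluoro-2-methoxyphenyl group of compound 3.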